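This account rests on a few compounds, and the source may have more. Where it says the series, first, only, none or still open, it means among the compounds named here.

Measured in a functional assay on MOLT-4 cells (Homo sapiens) for inhibition (a lower number here means a stronger inhibitor, a higher number a weaker inhibitor), so far:

Compound 1 `CC(C)C(NC(=O)NO)C(=O)NC1CCCC1` — > 200000 nM, a limit of the assay and not a number.
Compound 2 `CCC(C)C(NC(=O)n1nnc2ccccc21)C(=O)NC1CCCCC1` — 98000 nM.
Compound 3 `CC(C)C(NC(=O)n1nnc2ccccc21)C(=O)NC1CCCCC1` — 97000 nM.

Compounds 2 and 3 differ by one change, (methyl in place of hydrogen on a saturated chain carbon, three bonds along the chain from an amide-type nitrogen and a carbonyl carbon), and that change moved the number by a 1.0-fold higher number from compound 3 to compound 2 (0.00 log units; within the scatter). Compound 1 stands on a different core; the difference between the two cores is not broken down here. Compound 1 sits at the limit of > 200000 nM in this assay, at which 1 of the 3 values shown sits, so for it only a limit is known.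

Compound 4 `CCC(C)C(NC(=O)NO)C(=O)NC1CCCC1` is not yet measured. It differs from compound 1 by methyl in place of hydrogen on a saturated chain carbon, three bonds along the chain from an amide-type nitrogen and a carbonyl carbon, the same change that turns compound 3 into compound 2, with the same surroundings at the place of change. Since that change left the number of compound 3 essentially unchanged on the way to compound 2, the step of a number no higher from compound 1 to compound 4 (the limit leaves the size open) is expected to be small as well. Because compound 1 gives > 200000 nM, compound 4 is estimated to give about 200000 nM, most likely again only a limit, within a range from 100000 nM to 500000 nM in this assay.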

Compound 4, half-maximal inhibitory concentration: > 100000 nM
Compound 4: no number, only a limit (the forecaster's own chance of this, stated with the estimate: 80%); the middle value lies beyond the limit too.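

In this assay compound 4 gives > 100000 nM, a limit and not a number. Compound 1 also gives only a limit, > 200000 nM. With limits on both sides, no step can be read between compound 1 and compound 4. The compounds shown leave open how strongly either one inhibits, and whether methyl in place of hydrogen changes anything on the core of compound 1.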